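Moving the bromine on the aryl ether of compound 3

The source may report more compounds than this note shows. Statements on the series, on what has been measured and on what is new or still open speak of the compounds shown alone.

Measured so far in an assay on microsomes from liver for inhibition of acyl-CoA desaturase 1 (Rattus norvegicus); a higher number here means a weaker inhibitor, a lower number a stronger inhibitor:
compound 1, `COc1ccccc1OC1CCN(c2ccc(-n3ccnc3)nn2)CC1`, 543 nM
compound 2, `N#Cc1ccccc1OC1CCN(c2ccc(-n3ccnc3)nn2)CC1`, 236 nM
compound 3, `Brc1cccc(OC2CCN(c3ccc(-n4ccnc4)nn3)CC2)c1`, 23 nM

Compound 3 has the lowest number of the three in this assay; its nearest neighbour is compound 2, with a number higher by a 10-fold lower number from compound 2 to compound 3 (1.01 log units; beyond the scatter) in the other direction, and its furthest is compound 1, with a 24-fold lower number from compound 1 to compound 3 (1.37 log units; beyond the scatter) running the other way. Both of those steps are large and beyond the scatter.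

Compound 4, `Brc1ccccc1OC1CCN(c2ccc(-n3ccnc3)nn2)CC1`, differs from compound 3 in one place: 2-bromophenyl in place of 3-bromophenyl on an oxygen on a saturated carbon.

For the measured compounds named here, no measured pair here exchanges a 3-bromophenyl for a 2-bromophenyl, so the step has to be read indirectly. The two large steps, a 24-fold lower number from compound 1 to compound 3 (1.37 log units; beyond the scatter) and a 10-fold lower number from compound 2 to compound 3 (1.01 log units; beyond the scatter), both replace a 2-substituted phenyl with the 3-bromophenyl, and each gave a strongly lower number; the smaller step of a 2.3-fold lower number from compound 1 to compound 2 (0.36 log units; beyond the scatter) shows that the identity of the 2-substituent matters too, but only modestly. Compound 4 returns to a 2-substituted phenyl while keeping the bromine, so a higher number than that of compound 3 is expected, though probably not as high as those of compounds 1 or 2. For compound 4 the expected step is a 3.9-fold higher number from compound 3 to compound 4 (0.59 log units; beyond the scatter). The estimate for compound 4 in this assay is 90 nM, with a range from 30 nM to 270 nM.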

Compound 4, half-maximal inhibitory concentration: 5 nM
Beside the measured number, compound 4's estimate is 18-fold (1.26 log units) above it; measured number outside the range, below it.
By their numbers in this assay, from the lowest: compound 4; then compound 3; then compound 2; then compound 1.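

In this assay the change from 3-bromophenyl to 2-bromophenyl gives a 4.6-fold lower number from compound 3 to compound 4 (0.66 log units; beyond the scatter) and shows, with the bromine held constant, that a substituent at this place on the phenyl ring does not itself cost anything here. The earlier steps to compound 3 had changed the substituent and its place together, whereas with the place held fixed, bromo in place of cyano gives a 47-fold lower number from compound 2 to compound 4 (1.67 log units; beyond the scatter) and bromo in place of methoxy gives a 110-fold lower number from compound 1 to compound 4 (2.04 log units; beyond the scatter) so among these compounds the large gains follow the bromine and not the move away from that place. Nothing shown here offers an explanation for this order.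

On these data alone, whether chloro, methyl or trifluoromethyl on the same aromatic carbon would match the bromine remains open. As far as these compounds go, it is also open whether 3-methoxyphenyl and 3-cyanophenyl would stand to their 2-substituted partners as 3-bromophenyl stands to 2-bromophenyl, since a single pair cannot settle that.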